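From benzoate ester to nitrate

The source may hold more compounds than are shown below. What is called first, only, known or untested is meant among the compounds shown, and "the series" means these compounds.

Measured so far:
compound 1, `CC(=O)Oc1ccccc1C(=O)O[C@H]1CO[C@H]2[C@@H]1OC[C@H]2OC(=O)C1CC1`: 0.0322 h
compound 2, `CC(=O)Oc1ccccc1C(=O)O[C@H]1CO[C@H]2[C@@H]1OC[C@H]2OC(=O)c1ccccc1`: 0.055 h

Both compounds share a core carrying an acetylsalicylate ester on one hydroxyl, and they differ only in the group on the second hydroxyl. In an ADME assay on a cell-free system (plasma, Homo sapiens) for metabolic stability, with Plasma (Rattus norvegicus) as the target, read by HPLC, at pH 7.4 (a lower number here means that the compound disappears faster, a higher number that the compound lasts longer), compound 1 gives 0.0322 h, and compound 2 gives 0.055 h. Among the measured compounds shown here, the single measured step, a 1.7-fold higher number from compound 1 to compound 2 (0.23 log units; within the scatter), is within the scatter, so compound 2 stands at the higher of the two numbers without being separable from compound 1.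

Compound 3, `CC(=O)Oc1ccccc1C(=O)O[C@H]1CO[C@H]2[C@@H]1OC[C@H]2O[N+](=O)[O-]`, has not yet been measured in this assay. Its difference from compound 2 is: nitro in place of benzoyl on an oxygen on a saturated carbon.

For the measured compounds named here, the only measured step swaps one acyl group for another on a carbonyl carbon and stays within the scatter; none of the measured steps bears directly on replacing the whole acyl group by a nitro group on the oxygen. With the acetylsalicylate ester kept unchanged, the expectation for compound 3 is a step of a 1.1-fold lower number from compound 2 to compound 3 (0.04 log units; within the scatter), no change beyond the scatter. The estimate for compound 3 is 0.05 h, ranging from 0.02 h to 0.15 h.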

Compound 3, half-life: 0.0144 h
Beside the measured number, compound 3's estimate is 3.5-fold (0.54 log units) above it, and the stated range ends above it.
By their numbers in this assay, from the lowest: compound 3; then compounds 1 and 2 (each within the scatter of the next).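

Among the compounds shown here, compound 3 brings the first change at this position that moves the number in this assay beyond the scatter: the step is a 3.8-fold lower number from compound 2 to compound 3 (0.58 log units; beyond the scatter), and the step from the cyclopropyl ester is a 2.2-fold lower number from compound 1 to compound 3 (0.35 log units; beyond the scatter), both modest and both in the same direction. Compound 1 and compound 2 could not be told apart, so exchanging one acyl group for another had shown no effect, whereas nitro in place of either acyl group on an oxygen on a saturated carbon separates compound 3 from both while the acetylsalicylate ester stays unchanged; what is attached to this oxygen therefore does bear on how long these compounds last in this assay, at least across these three compounds. No accompanying measurement offers an account of why the nitrate lasts for a shorter time than the two esters.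

The three compounds leave open whether a free hydroxyl, an amine or a longer acyl chain on this oxygen would fall with the two esters or with the nitrate. They also leave open whether the same step from benzoyl to nitro would appear with a simple acetate or a carboxylic acid in place of the acetylsalicylate ester.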